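Two-ring core with benzyl substituents: chloro to amino exchange

The source may report more compounds than this note shows. Statements on the series, on what has been measured and on what is new or still open speak of the compounds shown alone.

Compound 1 `ClCc1ccccc1Cn1cnc2c(Cl)nc(Cl)nc21` is the more toxic of the two compounds measured in a functional assay on PC-3 cells (Homo sapiens) for cytotoxicity, read by sulforhodamine B assay, with a stated time of 48 h; on this read-out lower numbers stand for higher toxicity in this test and higher numbers for lower toxicity in this test. In this assay compound 1 gives 5120 nM. Compound 2 `ClCc1ccc(Cn2cnc3c(Cl)nc(Cl)nc32)cc1`, which carries the chloromethyl group at a different position of the benzyl ring, gives 45700 nM in this assay; the two values lie well apart, beyond the usual scatter, so compound 1 stands as the lower number of the pair and the benzyl substitution pattern of compound 1 is the better of the two seen so far.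

Compound 3 `Nc1nc(Cl)c2ncn(Cc3ccccc3CCl)c2n1` keeps the benzyl part of compound 1 and changes the core: amino in place of chloro on an aromatic carbon. Going by the values given here, no pair of measured compounds covers this exchange, so nothing in the data sets its size. For compound 3 the expectation is a moderate rise in the number, that is a loss of toxicity, with the step of a 2.3-fold higher number from compound 1 to compound 3 (0.37 log units; beyond the scatter) expected in this assay. For compound 3 a value near 12000 nM is estimated, with a range of 4000 nM to 40000 nM, and a limit read is not expected.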

Compound 3, concentration lethal to 50% of the cells: > 100000 nM
Compound 3: only a limit was reported (the forecaster's own chance of this, stated with the estimate: 5%); at least 8.3-fold (0.92 log units) between middle value and limit.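

The earlier pair differed only in where the chloromethyl group sits on the benzyl ring, so it said nothing about the core. With the benzyl part of compound 1 held constant, amino in place of chloro on the aromatic carbon between two ring nitrogen atoms gives an at least 19-fold higher number from compound 1 to compound 3 (1.29 log units; beyond the scatter), which shows that this single exchange on the core can by itself remove most of the toxicity seen in this assay. The step rests on a limit and not on a number, so it fixes only a minimum size and the full size stays unread, with the bound set by one reading: the limit of > 100000 nM in this assay, at which 1 of the 3 values shown sits.

The compounds shown leave open whether a methoxy or dimethylamino group on this carbon would keep the toxicity of compound 1 or follow compound 3, and so whether the loss is tied to the entering amino group or to the leaving chloro. Also open, as far as these compounds go, is whether the same exchange carries over to the benzyl pattern of compound 2, and what an amine would do in place of the remaining chloro group of the core.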